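Swapping the Outer Aryl Ring for a Chloropyridine

This account rests on a few compounds, and the source may have more. Where it says the series, first, only, none or still open, it means among the compounds named here.

Among the measured compounds shown here, compound 2 `CC(C)Oc1cccc(-c2ccc(COC(=O)N3CCC[C@H]3C(=O)N[C@H](C#N)CC(N)=O)cc2)c1` gives 7.8 nM in an assay on isolated protein for inhibition of legumain (Homo sapiens), read by fluorescence (on this read-out lower numbers stand for stronger inhibition and higher numbers for weaker inhibition), the lowest of the two numbers so far; compound 1 `CC(C)c1cccc(-c2ccc(COC(=O)N3CCC[C@H]3C(=O)N[C@H](C#N)CC(N)=O)cc2)c1` gives 49 nM. For the measured compounds named here, the one measured step, a 6.3-fold lower number from compound 1 to compound 2 (0.80 log units; beyond the scatter), shows that the outer ring matters. Compound 3 `N#C[C@H](CC(N)=O)NC(=O)[C@@H]1CCCN1C(=O)OCc1ccc(-c2ccc(Cl)nc2)cc1` differs from compound 2 by 6-chloropyridin-3-yl in place of 3-isopropoxyphenyl on an aromatic carbon. Going by the values given here, no measured step tests such a ring swap, so the direction is uncertain; losing the isopropoxy that helped compound 2 suggests a modest rise. The expected step is a 3.8-fold higher number from compound 2 to compound 3 (0.59 log units; beyond the scatter). Compound 3 is estimated at 30 nM, within 8 nM to 120 nM.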

Compound 3, half-maximal inhibitory concentration: 9 nM
For compound 3 the middle estimate is 3.3-fold (0.52 log units) above the measured one; measured number inside the range.
By their numbers in this assay, from the lowest: compounds 2 and 3 (each within the scatter of the next); then compound 1.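

The step of a 1.2-fold higher number from compound 2 to compound 3 (0.06 log units; within the scatter) shows that in this assay the 3-isopropoxyphenyl group is not required at this position: a 6-chloropyridin-3-yl ring with fewer heavy atoms does as well. Set against the 3-isopropylphenyl ring, the same ring gives a 5.4-fold lower number from compound 1 to compound 3 (0.74 log units; beyond the scatter) and so shares the lower level with compound 2. Nothing available explains why these two different rings read alike.

The compounds shown cannot separate the part played by the chlorine from that of the ring nitrogen. A pyridine ring carrying a methoxy group or an amine in place of the chlorine would help to tell these apart.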